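Microsomal clearance notes: three measured compounds, one unmeasured

The source may hold more compounds than are shown below. What is called first, only, known or untested is meant among the compounds shown, and "the series" means these compounds.

Compound 1 `CC[C@@H]1c2cc(Cl)ccc2C(=O)N1c1cncc2c1CCC[C@H]2NC(C)=O`: in an ADME assay on microsomes from liver (Mus musculus) for metabolic stability, read by LC-MS, using NADPH, with stated times of 10 min and 30 min (on this read-out lower numbers stand for slow clearance and higher numbers for fast clearance), compound 1 gives < 20.2 mL/min/kg, a limit of the assay.
Compound 2 `CC(=O)N[C@@H]1CCCc2c1cncc2N1Cc2cc(Cl)ccc2C1=O`: in this assay compound 2 gives < 20.2 mL/min/kg, a limit.
Compound 3 `CCC(=O)N[C@@H]1CCCc2c1cncc2N1Cc2cc(Cl)ccc2C1=O`: in this assay compound 3 gives < 20.2 mL/min/kg, a limit.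

Compound 3 stands only at a limit, and the two other values are limits as well, so the limit of < 20.2 mL/min/kg in this assay, at which 3 of the 3 values shown sit, is the whole picture. The change from compound 2 to compound 3 is methyl in place of hydrogen on a saturated chain carbon bound to a carbonyl carbon; its step is a step that the two limits leave unreadable from compound 2 to compound 3. The change from compound 2 to compound 1 is ethyl in place of hydrogen on a saturated ring carbon; its step is a step that the two limits leave unreadable from compound 2 to compound 1.

Compound 4 `CCC(=O)N[C@@H]1CCCc2c1cncc2N1C(=O)c2ccc(Cl)cc2[C@H]1CC` differs from compound 3 by ethyl in place of hydrogen on a saturated ring carbon, the same change as from compound 2 to compound 1, at the same place. That earlier step was unreadable, so the expected step that the limit leaves unreadable from compound 3 to compound 4 rests only on the limits above. Compound 4 is estimated at 15 mL/min/kg, between 5 mL/min/kg and 35 mL/min/kg, most likely again reported as a limit.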

Compound 4, clearance: 44.9 mL/min/kg
Estimate against measurement, compound 4: 3.0-fold (0.48 log units) below; the measured number lies above the stated range.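

In this assay, ethyl in place of hydrogen on a saturated ring carbon gives an at least 2.2-fold higher number from compound 3 to compound 4 (0.34 log units; beyond the scatter), while methyl in place of hydrogen on a saturated chain carbon bound to a carbonyl carbon gives an at least 2.2-fold higher number from compound 1 to compound 4 (0.34 log units; beyond the scatter). Each change therefore goes with a higher number when the compound already carries the other change, so the ethyl change did not carry over as a silent one from compound 2 to compound 3. The steps starting from compound 2 cannot be read, so the size of either change on compound 2 stays unknown, and the comparison between cores rests on one assay limit: the limit of < 20.2 mL/min/kg in this assay, at which 3 of the 4 values shown sit.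

On these data alone, whether a propyl chain or a longer chain behaves like ethyl on that saturated ring carbon remains open. So does whether an amine or a carboxylic acid in place of ethyl gives a lower number.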